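A few compounds are considered here, and "the series" means these few. Any claim that something is new, unique, unknown or untested is made for them only; others in the source may bear on it.

Measured so far:
Compound 1, `CN(C)C(=O)/C=C/[C@H]1C[C@@H](O)[C@@H](O)C1`: in an ADME assay on S2 cells (Drosophila melanogaster) for cytotoxicity, read by MTT assay (a higher number here means that more compound is needed for the effect, a lower number that less compound is needed), compound 1 gives > 250000 nM, a limit of the assay rather than a number.
Compound 2, `O=C(/C=C/[C@H]1C[C@@H](O)[C@@H](O)C1)Nc1ccccc1`: in this assay compound 2 gives > 200000 nM, also a limit.
Compound 3, `CNC(=O)/C=C/[C@H]1C[C@@H](O)[C@@H](O)C1`: in this assay compound 3 gives > 250000 nM, again a limit.

Compound 3 thus stands at a limit, as do the other two values. Compound 4, `O=C(/C=C/[C@H]1C[C@@H](O)[C@@H](O)C1)NO`, differs from it by hydroxy in place of methyl on an amide-type nitrogen. Two measured steps alter the same amide-type nitrogen, a step that the two limits leave unreadable from compound 1 to compound 3 and a step that the two limits leave unreadable from compound 2 to compound 3, and neither can be read because all three values sit at the limit of > 200000 nM in this assay, at which 1 of the 3 values shown sits, or (the limit of > 250000 nM in this assay, at which 2 of the 3 values shown sit). The expected step is therefore a number no higher from compound 3 to compound 4 (the limit leaves the size open), nothing beyond the scatter. Compound 4 is expected to give again only a limit, estimated near 250000 nM within 100000 nM to 1000000 nM.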

Compound 4, half-maximal effective concentration: > 250000 nM
Compound 4: only a limit was reported (the forecaster's own chance of this, stated with the estimate: 85%); the middle value sits exactly at the limit.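

Among these compounds, the values of compound 1, compound 2, compound 3 and compound 4 are all limits, and no step to compound 4 can be read. How much of any of these compounds is needed for the effect in this assay stays open, as does whether the group on the amide-type nitrogen changes that amount.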